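The source may report more compounds than this note shows. Statements on the series, on what has been measured and on what is new or still open speak of the compounds shown alone.

Compound 1 `O=C(O)c1nn(Cc2cc(Br)ccc2OCc2ccccc2)cc1Br` — in a functional assay on CHO-K1 cells for antagonist activity at prostaglandin E2 receptor EP1 subtype (Homo sapiens), read by FLIPR (a higher number here means a weaker inhibitor, a lower number a stronger inhibitor), compound 1 gives < 2000 nM, a limit of the assay.
Compound 2 `O=C(O)c1nn(Cc2cc(Br)ccc2OCc2ccccc2)cc1Cl` — compound 2 gives < 2000 nM, again a limit.
Compound 3 `Cc1cc(C(=O)O)nn1Cc1cc(Br)ccc1OCc1ccc(Cl)cc1Cl` — compound 3 gives 0.49 nM.

Compound 1 and compound 2 differ by chloro in place of bromo on an aromatic carbon. The step that the two limits leave unreadable from compound 1 to compound 2 cannot be read because of the limit of < 2000 nM in this assay, at which 2 of the 3 values shown sit. Compound 4 `Cc1cc(C(=O)O)nn1Cc1cc(Cl)ccc1OCc1ccc(Cl)cc1Cl` is not yet measured; it differs from compound 3 by chloro in place of bromo on an aromatic carbon. This is the same kind of change as that from compound 1 to compound 2, but not the same: there it falls on a five-membered aromatic ring with 2 nitrogen, here on a six-membered aromatic ring of carbon only, meta to a large group and para to a large group. The difference between the core of compound 1 and that of compound 3 is not broken down here. With no readable measured step to rest on, the expected change a 2.0-fold higher number from compound 3 to compound 4 (0.31 log units; beyond the scatter) is small. Compound 4 is therefore estimated at 1 nM, between 0.3 nM and 4 nM.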

Compound 4, inhibition constant: 0.55 nM
Compound 4: the middle estimate sits 1.8-fold (0.26 log units) above what was measured; low and high end bracket the measured number.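

In this assay, chloro in place of bromo on the six-membered aromatic ring of carbon only gives a 1.1-fold higher number from compound 3 to compound 4 (0.05 log units; within the scatter), so on this core the two halogens cannot be told apart. This is a single readable step, and it says nothing firm about other cores. The step from compound 1 to compound 2 falls on a different ring, a five-membered aromatic ring with 2 nitrogen, and it cannot be read: the limit of < 2000 nM in this assay, at which 2 of the 4 values shown sit.

Going by these compounds, whether the result of this swap carries over from one core to another therefore stays open. Also open, on these data alone, is how a nitrile or a methoxy group at the same place on the ring would read in this assay.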